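Trifluoromethoxy to hydroxy in a growth-inhibition series

This account rests on a few compounds, and the source may have more. Where it says the series, first, only, none or still open, it means among the compounds named here.

Going by the values given here, in a functional assay on PC-3 cells (Homo sapiens) for inhibition, read by sulforhodamine B assay (on this read-out higher numbers stand for weaker inhibition of growth and lower numbers for stronger inhibition of growth), compound 1 `Cc1ccc2[nH]c(-c3ccc(-c4ccc(-c5cccc(Cl)c5)cc4)cc3)nc2c1` gives 2670 nM and compound 2 `Cc1ccc2[nH]c(-c3ccc(-c4ccc(-c5ccc(OC(F)(F)F)cc5)cc4)cc3)nc2c1` gives 2010 nM, so compound 2 stands within the scatter of the only other number available. Compound 3 `Cc1ccc2[nH]c(-c3ccc(-c4ccc(-c5ccc(O)cc5)cc4)cc3)nc2c1` alters one group of compound 2, with hydrogen in place of trifluoromethyl on an oxygen on an aromatic ring, that is, trifluoromethoxy to hydroxy: hydrogen in place of trifluoromethyl on an oxygen on an aromatic ring. Among the compounds with values here, only one measured step bears on this, a 1.3-fold lower number from compound 1 to compound 2 (0.12 log units; within the scatter), where 4-(trifluoromethoxy)phenyl stands in place of 3-chlorophenyl, and it stays within the scatter. Within the data shown here, no measured compound carries a hydroxy group, so this is thin guidance. No shift beyond the scatter is expected in this assay, in either direction. The expected step is a 1.1-fold higher number from compound 2 to compound 3 (0.04 log units; within the scatter). For compound 3 the estimate is 2200 nM, with an expected range from 700 nM to 7000 nM.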

Compound 3, concentration for 50% growth inhibition: 30000 nM
The estimate for compound 3 lay 14-fold (1.13 log units) below the measured number, outside the stated range (above it).
By their numbers in this assay, from the lowest: compounds 2 and 1 (each within the scatter of the next); then compound 3.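

The earlier pair showed only that 4-(trifluoromethoxy)phenyl and 3-chlorophenyl give numbers within the scatter of each other, which could have suggested that this position is indifferent to the group it carries. In this assay the change from trifluoromethoxy to hydroxy brings a 15-fold higher number from compound 2 to compound 3 (1.17 log units; beyond the scatter) and so shows that the position is not indifferent. The comparison with the chloro compound gives an 11-fold higher number from compound 1 to compound 3 (1.05 log units; beyond the scatter) with 4-hydroxyphenyl in place of 3-chlorophenyl, so compound 3 stands apart from both earlier compounds, and nothing available explains this drop in growth inhibition.

As far as these compounds go, whether methoxy, which keeps a carbon on the oxygen, would stay with compound 2 or fall with compound 3 remains open. The same holds for an amine or a carboxylic acid at this position.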